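The source may hold more compounds than are shown below. What is called first, only, known or untested is meant among the compounds shown, and "the series" means these compounds.

Measured compounds:
compound 1 `CCCCC1([C@@H](O)/C=C/C2CCC(=O)[C@@H]2CCCCCCC(=O)OCC)CCC1`, 0.032 mg/kg
compound 2 `CCCCC1([C@H](O)/C=C/C2CCC(=O)[C@@H]2CCCCCCC(=O)OCC)CCC1`, 0.0151 mg/kg
compound 3 `CCCCC1([C@H](O)/C=C/C2[C@H](O)CC(=O)[C@@H]2C/C=C\CCCC(=O)O)CCC1`, 0.00154 mg/kg

In a functional assay on the whole organism (strain Hartley) for inhibition, with Cavia porcellus as the target, with stated times of 15 min and 2 min (a lower number here means that less compound is needed, a higher number that more compound is needed for the effect), compound 1 stands with the highest number of the three; compound 2 lies nearest, and the step of a 2.1-fold lower number from compound 1 to compound 2 (0.33 log units; beyond the scatter) is a change at a single stereocentre only. Among the compounds with values here, compound 3, with a much lower number, differs from compound 1 in several places at once, so no single step to it can be drawn. The unmeasured compound 4 `CCCCC1([C@@H](O)/C=C/C2CCC(=O)[C@@H]2CCCCSCC(=O)O)CCC1` arises from compound 1 by (carboxymethyl)sulfanyl in place of 2-(ethoxycarbonyl)ethyl on a saturated chain carbon, four bonds along the chain from a saturated ring carbon. Within the data shown here, no measured step alters this chain, so none bears directly on the change, and only a modest shift is anticipated. Compound 4 is therefore expected to give 0.02 mg/kg, within 0.005 mg/kg to 0.08 mg/kg. The expected step is a 1.6-fold lower number from compound 1 to compound 4 (0.20 log units; within the scatter).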

Compound 4, dose for half-maximal effect: 0.606 mg/kg
The estimate for compound 4 lay 30-fold (1.48 log units) below the measured number; the measured number lies above the stated range.
By their numbers in this assay, from the lowest: compound 3; then compound 2; then compound 1; then compound 4.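

In this assay, (carboxymethyl)sulfanyl in place of 2-(ethoxycarbonyl)ethyl gives a 19-fold higher number from compound 1 to compound 4 (1.28 log units; beyond the scatter). Within the data shown here, this is the first reading on this chain, and it shows that the number responds far more strongly to a change here than to the single stereocentre change among the earlier compounds. Nothing given here accounts for this step.

On these data alone, the change alters the sulfur, the chain length and the chain end together, so their separate contributions remain open. As far as these compounds go, how an amide or a longer sulfanyl chain would read at this place also remains open.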